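Swapping Benzylamino for Butylsulfanyl: Expected Cell Tolerance

A few compounds are considered here, and "the series" means these few. Any claim that something is new, unique, unknown or untested is made for them only; others in the source may bear on it.

Three compounds share one core and differ only in the group on one aromatic carbon: compound 1 `CCOc1nc(N)nc2c1ncn2/C=C1/CC1(CO)CO` carries ethoxy, compound 2 `CN(C)c1nc(N)nc2c1ncn2/C=C1/CC1(CO)CO` carries dimethylamino, and compound 3 `Nc1nc(NCc2ccccc2)c2ncn(/C=C3/CC3(CO)CO)c2n1` carries benzylamino. In an ADME assay on Akata cells (Homo sapiens) for cytotoxicity, with a stated time of 7 days (a higher number here means that more compound is tolerated, a lower number that less compound is tolerated), compound 1 gives > 20000 nM, which is a limit of the assay rather than a number. In this assay compound 2 gives > 24000 nM, likewise a limit. In this assay compound 3 gives > 24000 nM, also a limit. Compound 3 thus stands at a limit, described by the limit of > 24000 nM in this assay, at which 2 of the 3 values shown sit. The remaining value sits at the limit of > 20000 nM in this assay, at which 1 of the 3 values shown sits.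

Every step between these compounds is unreadable: a step that the two limits leave unreadable from compound 1 to compound 2, a step that the two limits leave unreadable from compound 1 to compound 3 and a step that the two limits leave unreadable from compound 2 to compound 3. None gives a size or a direction.

Compound 4 `CCCCSc1nc(N)nc2c1ncn2/C=C1/CC1(CO)CO` is the next compound, and its change from compound 3 is butylsulfanyl in place of benzylamino on an aromatic carbon. The two steps that reach compound 3, from compound 1 and from compound 2, are the ones that bear on this change, and both are unreadable, so no step beyond the scatter can be expected in this assay; the estimated step is a step that the limit leaves unreadable from compound 3 to compound 4. Compound 4 is therefore expected to give 30000 nM, within an estimated range of 10000 nM to 100000 nM.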

Compound 4, half-maximal cytotoxic concentration: > 20000 nM
Compound 4 was reported as a limit (the forecaster's own chance of this, stated with the estimate: 75%); the middle value lies beyond the limit too.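

No new step can be read from compound 1, compound 2 or compound 3 to compound 4, because compound 4, like the other three, is reported only as a limit of the assay: the limit of > 20000 nM in this assay, at which 2 of the 4 values shown sit.

The compounds shown leave open whether ethoxy, dimethylamino, benzylamino and butylsulfanyl differ at all in this assay, and at what concentration each compound harms the cells.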